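Variation of the group on the carbonyl carbon

The compounds below may be only part of what the source reports. "The series", "measured", "known", "first", "only" and "open" are said of these compounds alone.

The three measured compounds share one core and differ only in the group on the carbonyl carbon attached to the amide-type nitrogen in a ring. Compound 1 `Cc1nc(S(C)(=O)=O)ccc1Oc1ncnc(OC2CCN(C(=O)OC3CCC3)CC2)c1F` gives 167 nM in a functional assay on isolated protein for inhibition of Glucose-dependent insulinotropic receptor (Rattus norvegicus), read by HTRF and cAMP accumulation; a lower number here means that less compound is needed, a higher number that more compound is needed for the effect. Compound 2 `Cc1nc(S(C)(=O)=O)ccc1Oc1ncnc(OC2CCN(C(=O)O[C@@H](C)C(F)(F)F)CC2)c1F` gives 109 nM in this assay, and compound 3 `Cc1nc(S(C)(=O)=O)ccc1Oc1ncnc(OC2CCN(C(=O)SC3(C)CC3)CC2)c1F` gives 166 nM. Compound 3 stands second highest of the three numbers, all of which lie within the scatter of one another: the nearest is compound 1, with a 1.0-fold lower number from compound 1 to compound 3 (0.00 log units; within the scatter), and the furthest is compound 2, with a 1.5-fold higher number from compound 2 to compound 3 (0.18 log units; within the scatter). The remaining pair shows a 1.5-fold lower number from compound 1 to compound 2 (0.19 log units; within the scatter).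

Compound 4 `Cc1nc(S(C)(=O)=O)ccc1Oc1ncnc(OC2CCN(C(=O)C3CCCC3)CC2)c1F` is the next member. Relative to compound 3 the change is a group of 5 heavy atoms (5 carbon; one five-membered non-aromatic ring of carbon only) in place of a group of 5 heavy atoms (4 carbon, 1 sulfur; one three-membered non-aromatic ring of carbon only), on a carbonyl carbon. For the measured compounds named here, the steps that bear on it are the two already made at the same carbonyl carbon, a 1.0-fold lower number from compound 1 to compound 3 (0.00 log units; within the scatter) and a 1.5-fold higher number from compound 2 to compound 3 (0.18 log units; within the scatter), both within the scatter, as is a 1.5-fold lower number from compound 1 to compound 2 (0.19 log units; within the scatter). On this record no movement beyond the scatter is expected in this assay, so compound 4 is estimated at a 1.0-fold lower number from compound 3 to compound 4 (0.00 log units; within the scatter). The expected value for compound 4 is 165 nM, with a range from 80 nM to 340 nM.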

Compound 4, half-maximal effective concentration: 407 nM
The estimate for compound 4 lay 2.5-fold (0.39 log units) below the measured number; the whole stated range lies below it.
By their numbers in this assay, from the lowest: compounds 2, 3 and 1 (each within the scatter of the next); then compound 4.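

Notes on the carbonyl carbon attached to the amide-type nitrogen in a ring: cyclopentyl gives the first change at this position that lies beyond the scatter in this assay, with a 2.5-fold higher number from compound 3 to compound 4 (0.39 log units; beyond the scatter), a 2.4-fold higher number from compound 1 to compound 4 (0.39 log units; beyond the scatter) and a 3.7-fold higher number from compound 2 to compound 4 (0.57 log units; beyond the scatter). More compound is therefore needed for the effect with cyclopentyl than with any of the three earlier groups, although the step from compound 3 leaves the count of heavy atoms in the group unchanged. Compounds 1, 2 and 3, whose numbers lie within the scatter of one another, each carry an oxygen or a sulfur on the carbonyl carbon, whereas the cyclopentyl of compound 4 is all carbon, and no measurement at hand explains this step.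

Compound 4 differs from compound 1 in both ring size and the atom on the carbonyl carbon, so the compounds shown do not separate these two changes. Cyclopentyloxy, cyclobutyl or cyclopentylamino on the same carbonyl carbon would each bear on that question, and how far the number moves with such groups remains open.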